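This account rests on a few compounds, and the source may have more. Where it says the series, first, only, none or still open, it means among the compounds named here.

Compound 1 `O=S(=O)(Nc1ccc2oc(-c3ccccc3)nc2c1)c1ccc(Cl)cc1` gives > 63000 nM in an assay on isolated protein for inhibition of malate dehydrogenase, mitochondrial (Sus scrofa), with stated times of 45 min and 30 min; a lower number here means a stronger inhibitor, a higher number a weaker inhibitor.
Compound 2 `C=Cc1ccc(S(=O)(=O)Nc2ccc(-c3nc4ccccc4o3)cc2)cc1` gives > 63000 nM in this assay.
Compound 3 `O=S(=O)(Nc1ccc(-c2nc3ccccc3o2)cc1)c1cccc(C(F)(F)F)c1` gives > 63000 nM in this assay.

Each of these values is a limit of this assay and not a number: the measurement stops at the limit of > 63000 nM in this assay, at which 3 of the 3 values shown sit. Compound 2 therefore stands at the limit, as do the two other compounds shown; none of them can be ordered against another. Compound 4 `O=S(=O)(Nc1ccc(-c2nc3ccccc3o2)cc1)c1ccc(Cl)cc1` has not yet been measured. It differs from compound 2 by chloro in place of vinyl on an aromatic carbon. Going by the values given here, no measured pair shows this same change, so its size is not known from the data; compound 1 carries the same chloro group on a differently arranged core and also sits at the limit. The step from compound 2 to compound 4 is expected to be none beyond the scatter, a step that the limit leaves unreadable from compound 2 to compound 4. Compound 4 is estimated to give 100000 nM, between 40000 nM and 300000 nM, most likely again reported only as a limit.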

Compound 4, half-maximal inhibitory concentration: > 63000 nM
Compound 4: no number, only a limit; the forecaster's own chance of this, stated with the estimate: 85%; the middle value is on the limit's open side.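

No step can be read from compound 2 to compound 4, because both values are limits and not numbers: the limit of > 63000 nM in this assay, at which 4 of the 4 values shown sit.
In this assay the compounds shown leave open which structure, if any, would give a measured number and not a limit.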